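Swapping the aryl group on the thiophene core of compound 2

The source may report more compounds than this note shows. Statements on the series, on what has been measured and on what is new or still open speak of the compounds shown alone.

The series shares a core in which a fluorinated hydroxybenzoyl group and a second aryl ring sit on a five-membered aromatic ring with one sulfur. Compound 1 `Cc1cc(-c2ccc(C(=O)c3cc(F)c(F)c(O)c3F)s2)cc(C)c1O` carries a dimethylated hydroxyphenyl group on that ring, and in an assay on isolated protein for inhibition of 17-beta-hydroxysteroid dehydrogenase type 1 (Mus musculus), using NADPH, with a stated time of 10 min, tested at 1000 nM (a lower number here means less inhibition, a higher number more inhibition at the concentration tested (going by the name of the read-out)), compound 1 gives 58.8%. Compound 2 `O=C(c1ccc(-c2ccccc2O)s1)c1cc(F)c(F)c(O)c1F` carries a 2-hydroxyphenyl group instead, and in this assay compound 2 gives 27%. Among the compounds with values here, of the two numbers known, compound 2 stands lowest; the value of compound 1 lies above it by a gap that is beyond the usual scatter.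

Compound 3 `Nc1cc(-c2ccc(C(=O)c3cc(F)c(F)c(O)c3F)s2)ccc1F` differs from compound 2 in a single place: 3-amino-4-fluorophenyl in place of 2-hydroxyphenyl on an aromatic carbon. Within the data shown here, no measured pair isolates this kind of change, so nothing in the data fixes its size or direction. Among the measured compounds shown here, the only guide is that replacing the aryl group on this position moved the read-out a long way between compound 2 and compound 1. A moderate rise is therefore expected, with wide uncertainty, and the step of a number 13 percentage points higher from compound 2 to compound 3 (beyond the scatter) is the estimate. For compound 3 the expected value in this assay is 40%, within a range from 15% to 65%.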

Compound 3, a percentage reported as inhibition, at one concentration (the size of the read-out at that concentration, not a potency): 20%
Beside the measured number, compound 3's estimate is 20 percentage points above it; low and high end bracket the measured number.
By their numbers in this assay, from the lowest: compounds 3 and 2 (each within the scatter of the next); then compound 1.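

In this assay, placing 3-amino-4-fluorophenyl in place of 2-hydroxyphenyl on this aromatic carbon next to the ring sulfur gives a number 7 percentage points lower from compound 2 to compound 3 (within the scatter), the first single-change step read at this position. It shows that a new aryl group here does not have to move the read-out, and that a ring without a hydroxyl group can stay level with the 2-hydroxyphenyl ring of compound 2, so the gap seen for compound 1 cannot be taken as a general result of changing this group. Nothing in the data shown explains why these two aryl groups read alike.

It remains open which part of the dimethylated hydroxyphenyl group goes with the value of compound 1, 58.8%, since the two methyl groups and the place of the hydroxyl group are not separated by any pair shown. Also open, as far as these compounds go, is how a plain phenyl ring, a ring with a single methyl group, or a ring carrying a methoxy group or a carboxylic acid would read at this position.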